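Replacing ethyl with diethylamino in compound 3

A few compounds are considered here, and "the series" means these few. Any claim that something is new, unique, unknown or untested is made for them only; others in the source may bear on it.

In a functional assay on the whole organism for antagonist activity, with Mus musculus as the target (a lower number here means that less compound is needed, a higher number that more compound is needed for the effect), compound 1 `CC(=O)NCC(=O)N(C)c1ccc(Cl)cc1C(=O)c1ccccc1Cl` gives 2.3 mg/kg, compound 2 `CCC(=O)NCC(=O)N(C)c1ccc(Cl)cc1C(=O)c1ccccc1Cl` gives 1.4 mg/kg and compound 3 `CCCC(=O)NCC(=O)N(C)c1ccc(Cl)cc1C(=O)c1ccccc1Cl` gives 0.98 mg/kg. Compound 3 therefore stands level with compound 2, as a 1.4-fold lower number from compound 2 to compound 3 (0.15 log units; within the scatter) shows. The step of a 1.6-fold lower number from compound 1 to compound 2 (0.22 log units; within the scatter) also stays within the scatter, and only a 2.3-fold lower number from compound 1 to compound 3 (0.37 log units; beyond the scatter) goes beyond it. Compound 4 `CCN(CC)CC(=O)NCC(=O)N(C)c1ccc(Cl)cc1C(=O)c1ccccc1Cl` carries diethylamino in place of ethyl on a saturated chain carbon bound to a carbonyl carbon, with diethylamino in place of ethyl on a saturated chain carbon bound to a carbonyl carbon. The measured steps added only carbon, so they offer weak guidance for a change that brings in nitrogen. A modest move in this assay towards a higher number is expected, a 2.0-fold higher number from compound 3 to compound 4 (0.31 log units; beyond the scatter). For compound 4 the estimated value is 2 mg/kg, with an expected range from 0.6 mg/kg to 7 mg/kg.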

Compound 4, dose for half-maximal effect: 2.2 mg/kg
Compound 4: middle estimate off by 1.1-fold (0.04 log units), on the low side, within the range that was stated.
By their numbers in this assay, from the lowest: compounds 3, 2, 4 and 1 (each within the scatter of the next, the first and the last beyond it).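

In this assay, the saturated chain carbon bound to a carbonyl carbon also accepts diethylamino, which brings in nitrogen, but the low number of compound 3 does not carry over (a 2.2-fold higher number from compound 3 to compound 4 (0.35 log units; beyond the scatter)). Compound 4 stands level with the shorter carbon-chain compounds (a 1.6-fold higher number from compound 2 to compound 4 (0.20 log units; within the scatter); a 1.0-fold lower number from compound 1 to compound 4 (0.02 log units; within the scatter)). Nothing available here explains this result. From the compounds shown here alone, whether a smaller amine such as dimethylamino, or a ring amine such as piperidine, would behave like diethylamino remains open. So does the effect of a longer carbon chain such as butyl.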